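Swapping a hydroxyurea for an acylbenzotriazole on a diphenylmethyl amide

A few compounds are considered here, and "the series" means these few. Any claim that something is new, unique, unknown or untested is made for them only; others in the source may bear on it.

The study compares two measured compounds in a functional assay on MIA PaCa-2 cells (Homo sapiens) for inhibition (on this read-out higher numbers stand for weaker inhibition and lower numbers for stronger inhibition), and looks ahead to a third. Compound 1, `CCC(C)C1NC(=O)N(C2CCCCC2)C1=O`, is a cyclic urea with a cyclohexyl group; in this assay compound 1 gives only a limit, > 100000 nM, and not a number. For the measured compounds named here, compound 2, `CCC(C)C(NC(=O)NO)C(=O)NC(c1ccccc1)c1ccccc1`, opens this to a hydroxyurea carrying a diphenylmethyl amide; in this assay compound 2 gives 63800 nM, the only real number in the set. The other value, that of compound 1, is a limit of the assay, (the limit of > 100000 nM in this assay, at which 1 of the 2 values shown sits).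

Compound 3, `CCC(C)C(NC(=O)n1nnc2ccccc21)C(=O)NC(c1ccccc1)c1ccccc1`, keeps the diphenylmethyl amide and the branched side chain of compound 2 but changes the acyl end: a group of 9 heavy atoms (6 carbon, 3 nitrogen; one five-membered aromatic ring with 3 hetero atoms, one six-membered aromatic ring of carbon only) in place of a group of 2 heavy atoms (1 nitrogen, 1 oxygen; no ring), on a carbonyl carbon. The hydroxyamino group leaves, and the entering group brings a bicyclic aromatic system with three ring nitrogens and no donors. Going by the values given here, no step between measured compounds is given that resembles this change, so the expectation rests on compound 2 alone. A modest gain beyond the scatter is expected, a 1.6-fold lower number from compound 2 to compound 3 (0.20 log units; within the scatter), without confidence in its direction. In this assay compound 3 is estimated at 40000 nM, within 8000 nM to 150000 nM.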

Compound 3, half-maximal inhibitory concentration: 69300 nM
Compound 3: the middle estimate sits 1.7-fold (0.24 log units) below what was measured; the measured number falls inside the stated range.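

In this assay the exchange on the carbonyl carbon gives a 1.1-fold higher number from compound 2 to compound 3 (0.04 log units; within the scatter), so the two compounds read alike even though the entering group is a bicyclic aromatic system far larger than the hydroxyamino group it replaces. For the compounds shown here, this is the first one-place comparison in the set, and it shows that the hydroxyamino group is not required for the level of inhibition seen with compound 2, since a group without hydrogen-bond donors serves equally well at this place on this read-out. Compound 1 still gives only a limit and not a number, so it adds no comparison to this step: the limit of > 100000 nM in this assay, at which 1 of the 3 values shown sits.

The compounds shown leave open whether a simple amine or a methoxy group on the same carbonyl carbon would read any differently, and whether any group at this place can move the number beyond the scatter. Going by these compounds alone, they also leave open how much the diphenylmethyl amide contributes, as no compound here replaces it with, for example, a benzyl amide while keeping the rest unchanged.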